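Shorter Thioether Chain on a Single-Phosphate Nucleotide

This account rests on a few compounds, and the source may have more. Where it says the series, first, only, none or still open, it means among the compounds named here.

Compound 1 `O=c1ccn([C@@H]2O[C@H](COP(=O)(O)O)[C@@H](O)[C@H]2O)c(SCCc2ccccc2)n1` was tested in an in vitro functional assay on 1321-N1 cells for agonist activity at P2Y purinoceptor 6 (Homo sapiens), read by scintillation proximity assay and inositol phosphate accumulation; on this read-out lower numbers stand for an effect already at smaller amounts and higher numbers for an effect only at larger amounts of compound. For compound 1 only a limit is known: in this assay compound 1 gives > 100000 nM, which is the limit of the measurement rather than a number. Compound 2 `O=c1ccn([C@@H]2O[C@H](COP(=O)(O)OP(=O)(O)O)[C@@H](O)[C@H]2O)c(SCCc2ccccc2)n1` carries one more phosphate group, and in this assay compound 2 gives 2500 nM. Among the measured compounds shown here, that single measured step, an at least 40-fold lower number from compound 1 to compound 2 (1.60 log units; beyond the scatter), is the only comparison available, and its starting point sits at the limit of > 100000 nM in this assay, at which 1 of the 2 values shown sits. For the measured compounds named here, compound 3 `CCCSc1nc(=O)ccn1[C@@H]1O[C@H](COP(=O)(O)O)[C@@H](O)[C@H]1O` keeps the single phosphate of compound 1 and changes the thioether chain: methyl in place of phenyl on a saturated chain carbon, two bonds along the chain from a sulfur. Going by the values given here, no measured step touches this kind of change, so no direction can be read from the data. Compound 3 lacks the added phosphate, and compound 3 is therefore expected to remain near the limit, an expected step that the limit leaves unreadable from compound 1 to compound 3. The estimate for compound 3 in this assay is 150000 nM, within a range from 40000 nM to 1000000 nM.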

Compound 3, half-maximal effective concentration: 6200 nM
Estimate against measurement, compound 3: 24-fold (1.38 log units) above, outside the stated range (below it).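

In this assay, methyl in place of phenyl on a saturated chain carbon, two bonds along the chain from a sulfur, gives an at least 16-fold lower number from compound 1 to compound 3 (1.20 log units; beyond the scatter). Among the compounds shown here, this shows that the group at this place on the thioether chain strongly affects the read-out, and that a compound with a single phosphate can give a measurable number, which among the earlier compounds was seen only once the added phosphate was present. Compound 1 sits at a limit and not at a number, so the full size of this step remains unknown: the limit of > 100000 nM in this assay, at which 1 of the 3 values shown sits.

The compounds shown leave open whether a longer chain such as butyl, or a chain ending in an amine, would shift the number further in either direction. They also leave open what the added phosphate would do when paired with the propylsulfanyl chain.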